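A Fluorine Added to a Weak Inhibitor

A few compounds are considered here, and "the series" means these few. Any claim that something is new, unique, unknown or untested is made for them only; others in the source may bear on it.

Compound 1 `COc1ccc2nc(Nc3ccnc(Nc4ccc(S(N)(=O)=O)cc4)n3)sc2c1` gives 11000 nM in a functional assay on MCF7 cells (Homo sapiens) for antiproliferative activity, read by MTT assay, with a stated time of 48 h; a lower number here means a stronger inhibitor, a higher number a weaker inhibitor. Compound 2 `COc1ccc2nc(Nc3ccnc(Nc4ccc(S(C)(=O)=O)cc4)n3)sc2c1` reaches only a limit of this assay, > 50000 nM, so its true number is not known (the limit of > 50000 nM in this assay, at which 1 of the 3 values shown sits). Compound 3 `CS(=O)(=O)c1ccc(Nc2nccc(Nc3nc4ccccc4s3)n2)cc1` gives 10600 nM. The step of an at least 4.5-fold higher number from compound 1 to compound 2 (0.65 log units; beyond the scatter) shows methyl in place of amino on a sulfonyl sulfur weakening the inhibitor, while an at least 4.7-fold lower number from compound 2 to compound 3 (0.67 log units; beyond the scatter) shows hydrogen in place of methoxy on an aromatic carbon strengthening it again. Compound 4 `COc1ccc2nc(Nc3nc(Nc4ccc(S(C)(=O)=O)cc4)ncc3F)sc2c1` differs from compound 2 in one place: fluoro in place of hydrogen on an aromatic carbon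

Neither measured step touches fluoro, so no size or direction is indicated for this change, and compound 2 itself stands only as a limit. For compound 4 the expected value is 45000 nM, within 15000 nM to 150000 nM. The expected step is an at least 1.1-fold lower number from compound 2 to compound 4 (0.04 log units; that floor lies within the scatter).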

Compound 4, half-maximal inhibitory concentration: 5850 nM
Compound 4: the middle estimate sits 7.7-fold (0.89 log units) above what was measured, outside the stated range (below it).
By their numbers in this assay, from the lowest: compounds 4, 3 and 1 (each within the scatter of the next). At a limit, above all of these: compound 2.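

In this assay, fluoro in place of hydrogen gives an at least 8.5-fold lower number from compound 2 to compound 4 (0.93 log units; beyond the scatter) on this aromatic carbon of the six-membered ring with 2 nitrogen, the first change shown at this position. A single fluorine here is therefore enough to turn a compound stuck at the limit into one with a measurable number. As far as these compounds go, compound 2 is only a limit, so the step is a floor and its full size remains unknown: the limit of > 50000 nM in this assay, at which 1 of the 4 values shown sits.

From the compounds shown here alone, whether chloro, methyl or an amine on this carbon would give a similar number remains open. So does whether fluoro would have the same effect on compound 1 or compound 3.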